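Adding Chlorine to Compound 2: Expecting No Change

The source may hold more compounds than are shown below. What is called first, only, known or untested is meant among the compounds shown, and "the series" means these compounds.

Of the compounds shown here, three have been tested in a functional assay on HL-60 cells (Homo sapiens) for cytotoxicity, read by MTT assay, with a stated time of 72 h; a lower number here means a stronger inhibitor, a higher number a weaker inhibitor. Compound 1 `CCOc1ccc(COc2c(OC)cc(/C=C/C(=O)N3CCN(Cc4ccc(Cl)c(Cl)c4)CC3)cc2OC)cc1` gave only a limit, > 200000 nM, so no number could be assigned to it. Compound 2 `CCOc1ccc(COc2c(OC)cc(/C=C/C(=O)OCC(=O)Nc3ccccc3)cc2OC)cc1` likewise gave only a limit, > 200000 nM. Compound 3 `O=C(COC(=O)/C=C/c1ccc(O)c(O)c1)NN1CCOCC1` also returned only a limit, > 200000 nM. Compound 2 therefore stands exactly where the other two stand, namely at the limit of > 200000 nM in this assay, at which 3 of the 3 values shown sit, and no ordering among the three is possible since none shows measurable cytotoxicity.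

Compound 4 `CCOc1ccc(COc2c(OC)cc(/C=C/C(=O)OCC(=O)Nc3ccc(Cl)cc3)cc2OC)cc1` is not yet measured. It differs from compound 2 in one place: chloro in place of hydrogen on an aromatic carbon. Within the data shown here, no step between measured compounds is available to guide the guess, so the expectation rests on compound 2 alone, which sits at the limit with > 200000 nM. Compound 4 is expected to remain at the limit, with an estimated value of 200000 nM and a plausible range from 100000 nM to 500000 nM. The expected step of a number no higher from compound 2 to compound 4 (the limit leaves the size open) is none beyond the usual scatter.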

Compound 4, half-maximal inhibitory concentration: > 200000 nM
Compound 4: only a limit was reported; the forecaster's own chance of this, stated with the estimate: 80%; the middle value sits exactly at the limit.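

Among these compounds, compound 2 and compound 4 each give only a limit, so swapping hydrogen for chloro on the aromatic ring yields no step that can be read. What change, if any, would bring a measurable value in this assay stays open, with every compound shown resting at one limit: the limit of > 200000 nM in this assay, at which 4 of the 4 values shown sit.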